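Piperazine in place of hydroxypiperidine at the chain end

The source may hold more compounds than are shown below. What is called first, only, known or untested is meant among the compounds shown, and "the series" means these compounds.

Of the compounds shown here, two have been measured in a functional assay on the whole organism with Mus musculus as the target, in the maximal electroshock model, at a dose of 50 mg/kg by the oral route; on this read-out lower numbers stand for less inhibition and higher numbers for more inhibition at the one dose given (going by the name of the read-out). Compound 1 `C(=C/c1ccccc1OCCCCN1CCCC1)\c1ccccc1` gives 42.9%, whereas compound 2 `OC1CCN(CCCCOc2ccccc2/C=C/c2ccccc2)CC1` gives 0%, the lowest of the two numbers and set apart from compound 1 by a number 42.9 percentage points lower from compound 1 to compound 2 (beyond the scatter). Compound 3 `C(=C/c1ccccc1OCCCCN1CCNCC1)\c1ccccc1` has not yet been measured; it differs from compound 2 by piperazin-1-yl in place of 4-hydroxypiperidin-1-yl on a saturated chain carbon, four bonds along the chain from an oxygen on an aromatic ring. For the measured compounds named here, no measured step covers this exact change, so the only guidance comes from the single step between compound 1 and compound 2, which shows that exchanging the saturated ring at this position can move the read-out by a large amount. Because compound 2 stands at 0%, the writer expects the change toward compound 3 to go upward, if anywhere, but with wide uncertainty. Compound 3 is therefore estimated at 20%, within a range of 0% to 50%, corresponding to an expected step of a number 20 percentage points higher from compound 2 to compound 3 (beyond the scatter).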

Compound 3, a percentage reported as inhibition, in the whole organism at one dose (the size of the read-out at that dose, not a potency): 0%
For compound 3 the middle estimate is 20 percentage points above the measured one; the range from low to high includes it.
By their numbers in this assay, from the lowest: compounds 2 and 3 (each within the scatter of the next); then compound 1.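

In this assay the exchange of 4-hydroxypiperidin-1-yl for piperazin-1-yl reads no change at the digits printed from compound 2 to compound 3 (within the scatter) and the exchange of pyrrolidin-1-yl for piperazin-1-yl reads a number 42.9 percentage points lower from compound 1 to compound 3 (beyond the scatter) at the same saturated chain carbon. The large drop seen earlier therefore does not belong to 4-hydroxypiperidin-1-yl alone, since a second six-membered non-aromatic ring at this place gives the same reading, and of these three compounds only compound 1, with its pyrrolidin-1-yl group, stands apart. Nothing available explains this result.

The three compounds cannot separate the effect of ring size from that of the added hetero atom in each six-membered ring. Going by these compounds, whether plain piperidin-1-yl, morpholin-4-yl or an open dimethylamino group would match compound 1 stays open, as does the effect of a shorter or longer chain.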